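Three limits, and a fourth aryl group to test

The compounds below may be only part of what the source reports. "The series", "measured", "known", "first", "only" and "open" are said of these compounds alone.

Measured so far in an ADME assay on BJ cells (Homo sapiens) for cytotoxicity, with a stated time of 72 h; a lower number here means that less compound is needed, a higher number that more compound is needed for the effect
Compound 1 `Cc1cccc(-c2nc3c(c(C)nn3-c3ccccc3)c(-c3ccccc3O)c2C#N)c1` gives the limit > 20000 nM
Compound 2 `Cc1nn(-c2ccccc2)c2nc(-c3ccc(Cl)cc3)c(C#N)c(-c3ccccc3O)c12` gives the limit > 20000 nM
Compound 3 `Cc1nn(-c2ccccc2)c2nc(-c3ccc([N+](=O)[O-])cc3)c(C#N)c(-c3ccccc3O)c12` gives the limit > 20000 nM

Compound 3 stands at the limit > 20000 nM and has no exact number. It is not alone, since the record so far is the limit of > 20000 nM in this assay, at which 3 of the 3 values shown sit, and nothing finer.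

Compound 4 `Cc1nn(-c2ccccc2)c2nc(-c3ccc4c(c3)OCCO4)c(C#N)c(-c3ccccc3O)c12` carries 2,3-dihydro-1,4-benzodioxin-6-yl in place of 4-nitrophenyl on an aromatic carbon next to the ring nitrogen (the counted difference is 2,3-dihydro-1,4-benzodioxin-6-yl in place of 4-nitrophenyl on an aromatic carbon and the rest of the molecule stays the same).

Among the compounds with values here, three measured steps bear on this change, namely a step that the two limits leave unreadable from compound 1 to compound 2 and a step that the two limits leave unreadable from compound 1 to compound 3 and a step that the two limits leave unreadable from compound 2 to compound 3 and none of them has a readable size. Each aryl group measured so far left the read-out at the limit, so no step beyond the scatter is expected, and no direction can be argued.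

In this assay the expected result is a step that the limit leaves unreadable from compound 3 to compound 4 and nothing larger.

Compound 4 is estimated at 22000 nM with an expected range from 12000 nM to 40000 nM and the assay will probably report only a limit again.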

Compound 4, half-maximal effective concentration: > 20000 nM
Compound 4: a limit, no number; the forecaster's own chance of this, stated with the estimate: 85%; the middle value does not contradict the limit.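

In this assay compound 4 gives > 20000 nM, a limit and not a number. The steps to compound 4 from compound 1, compound 2 and compound 3 therefore cannot be read: the limit of > 20000 nM in this assay, at which 4 of the 4 values shown sit.

The compounds shown leave open how much of any of them is needed for the effect, and whether any other aryl group at this place would give an exact number.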